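The source may report more compounds than this note shows. Statements on the series, on what has been measured and on what is new or still open speak of the compounds shown alone.

Working notes on the series. Compound 1 `ONc1ccc(CNc2cc(Br)cc3[nH]ncc23)cc1` gives, in an assay for inhibition of Indoleamine 2,3-dioxygenase 1 (Homo sapiens), with a stated time of 1 h, tested at 10 uM (a higher number here means more inhibition at the concentration tested (going by the name of the read-out), a lower number less inhibition), the entry "not active" (no number reported), a qualitative report with no number attached. Among the compounds with values here, compound 2 `ONc1cccc(CNc2cc(Br)cc3[nH]ncc23)c1` in this assay gives 53%, the only numerical value so far, so it stands alone as the reference point. Compound 3 `O=C1CCCC(Nc2cccc(CNc3cc(Br)cc4[nH]ncc34)c2)C1`, not yet measured, carries the change (3-oxocyclohexyl in place of hydroxy on a nitrogen on an aromatic ring). Within the data shown here, no step between two measured compounds exists to calibrate this move, so the expectation rests on the size of the change alone. A drop beyond the usual scatter is expected, a number 33 percentage points lower from compound 2 to compound 3 (beyond the scatter). For compound 3 the estimate in this assay is 20%, with a range from 0% to 48%.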

Compound 3, a percentage reported as inhibition, at one concentration (the size of the read-out at that concentration, not a potency): 52%
Estimate against measurement, compound 3: 32 percentage points below; measured number above the stated range.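

In this assay, the nitrogen on the aromatic ring accepts a much larger group than hydroxy: 3-oxocyclohexyl, with 7 heavy atoms and a ring, gives a number 1 percentage points lower from compound 2 to compound 3 (within the scatter) and so leaves the read-out level. The entering group has no hydrogen-bond donor, so the donor of the hydroxy is not required to hold inhibition at this level in this pair. Nothing measured here bears on why the two compounds stand level.

Still open, as far as these compounds go, is whether the carbonyl matters, which an unsubstituted cyclohexyl group would test. An open butyl chain or a ring carrying a carboxylic acid on this nitrogen would show how far the position extends.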